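This account rests on a few compounds, and the source may have more. Where it says the series, first, only, none or still open, it means among the compounds named here.

In an ADME assay on CEMx174 cells (Homo sapiens) for cytotoxicity (a lower number here means that less compound is tolerated, a higher number that more compound is tolerated), compound 1 `CC1=C(C(=O)OCC2CCCCC2)C(c2cccc(O)c2)NC(=O)N1C` gives > 10000 nM, which is a limit of the assay and not a number. Compound 2 `CCC1=C(C(=O)OCC2CCCCC2)C(c2cccc(N)c2)NC(=O)N1` gives > 10000 nM, also a limit. Compound 3 `CCC1=C(C(=O)OCC2CCCCC2)C(c2ccc(N)cc2)NC(=O)N1` gives > 10000 nM, again a limit, so its true position is not known, only the side of the limit on which it lies.

Compound 4 `CCC1=C(C(=O)OCC2CCCCC2)C(c2ccc(C(=O)O)cc2)NC(=O)N1` keeps the core of compound 3 and carries carboxy in place of amino on an aromatic carbon, para to a large group: carboxy in place of amino on an aromatic carbon. Among the compounds with values here, the new group is larger than the one it replaces, but no measured pair makes this same change.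

Within the data shown here, the one measured step between close relatives is a step that the two limits leave unreadable from compound 2 to compound 3, and it involves a different change, so it gives no size to carry over. What remains is the shared result, (the limit of > 10000 nM in this assay, at which 3 of the 3 values shown sit). Nothing in these compounds points to a fall in the tolerated concentration, and the expectation is that this change will not produce one either. The expected move in this assay is a step that the limit leaves unreadable from compound 3 to compound 4, and this estimate carries no firm direction. A reported limit is the most likely outcome. For compound 4 the estimated value is 20000 nM, with an expected range from 10000 nM to 100000 nM.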

Compound 4, half-maximal cytotoxic concentration: > 10000 nM
Compound 4 gave a limit, no number; the forecaster's own chance of this, stated with the estimate: 80%; the middle value does not contradict the limit.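

With compound 4 also reported as a limit in this assay, the steps to it from compound 2 and compound 3 cannot be read, and no size can be given for either: the limit of > 10000 nM in this assay, at which 4 of the 4 values shown sit. The compounds shown leave open the concentration at which any of them would become toxic to these cells, and whether carboxy and amino differ in this respect.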